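The compounds below may be only part of what the source reports. "The series", "measured", "known", "first", "only" and "open" are said of these compounds alone.

Compound 1 `CC(C)(N)C(=O)N[C@H](COCc1ccccc1Cl)c1nnnn1CCOC(=O)NCCCCO`: 0.45 nM
Compound 2 `CC(C)(N)C(=O)N[C@H](COCc1cccc(Cl)c1)c1nnnn1CCOC(=O)NCCCCO`: 1.6 nM

Going by the values given here, in a functional assay on cells for inhibition of growth hormone secretagogue receptor type 1 (Homo sapiens), read by FLIPR and calcium flux (a lower number here means that less compound is needed, a higher number that more compound is needed for the effect), compound 1 gives 0.45 nM, the lower of the two numbers so far. Compound 2 gives 1.6 nM; the step is a 3.6-fold higher number from compound 1 to compound 2 (0.55 log units; beyond the scatter). Compound 3 `CC(C)(N)C(=O)N[C@H](COCc1cc(Cl)cc(Cl)c1)c1nnnn1CCOC(=O)NCCCCO` has not yet been measured. It differs from compound 1 in one place: 3,5-dichlorophenyl in place of 2-chlorophenyl on a saturated chain carbon bound to an oxygen on a saturated carbon. Among the compounds with values here, only one measured step bears on this change, the one from compound 1 to compound 2, where a 3-chlorophenyl in place of a 2-chlorophenyl gave a 3.6-fold higher number from compound 1 to compound 2 (0.55 log units; beyond the scatter). Within the data shown here, compound 3 also carries chlorine away from the place it has in compound 1, with a second chlorine added, and no measured pair shows what that second chlorine does. A modest rise of about the same size as in that step is therefore expected. Compound 3 is estimated to give 2 nM, with a range from 0.6 nM to 7 nM. The expected step is a 4.4-fold higher number from compound 1 to compound 3 (0.65 log units; beyond the scatter).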

Compound 3, half-maximal effective concentration: 6.75 nM
For compound 3 the middle estimate is 3.4-fold (0.53 log units) below the measured one; measured number inside the range.
By their numbers in this assay, from the lowest: compound 1; then compound 2; then compound 3.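

In this assay, the second chlorine is not neutral: chloro in place of hydrogen on an aromatic carbon gives a 4.2-fold higher number from compound 2 to compound 3 (0.63 log units; beyond the scatter). Taken as a whole, the change from 2-chlorophenyl to 3,5-dichlorophenyl on a saturated chain carbon bound to an oxygen on a saturated carbon gives a 15-fold higher number from compound 1 to compound 3 (1.18 log units; beyond the scatter), a large step, so among these three compounds the 2-chlorophenyl of compound 1 needs the least compound for the effect. No measurement here offers an explanation for these steps.

The compounds shown leave open what a second chlorine does when added to the 2-chlorophenyl of compound 1 rather than to the 3-chlorophenyl of compound 2. They also leave open how an unsubstituted phenyl, or a ring carrying fluorine or a methoxy group instead of chlorine, would compare.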